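Thiophene for phenol on the enone chain

The source may report more compounds than this note shows. Statements on the series, on what has been measured and on what is new or still open speak of the compounds shown alone.

Measured so far:
compound 1 `O=C(/C(=C\c1ccc(O)cc1)SCc1ccc(Cl)cc1)c1ccc(Br)cc1` — 10000 nM
compound 2 `O=C(/C(=C\c1ccc(O)cc1)S(=O)(=O)Cc1ccc(Cl)c(Cl)c1)c1ccc(Cl)cc1` — 10000 nM

In a functional assay on DU-145 cells (Homo sapiens) for inhibition, read by trypan blue exclusion, with a stated time of 96 h (a lower number here means a stronger inhibitor of growth, a higher number a weaker inhibitor of growth), compound 1 gives 10000 nM. In this assay compound 2 gives 10000 nM. Compound 1 stands level with compound 2 at the digits shown; the two values lie within the scatter of each other, so no order between them can be read.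

Compound 3 `Cc1ccsc1/C=C(/SCc1ccc(Cl)cc1)C(=O)c1ccc(Br)cc1` has not yet been measured in this assay. It differs from compound 1 in one place: 3-methylthiophen-2-yl in place of 4-hydroxyphenyl on a double-bonded chain carbon bound to a double-bonded chain carbon. Within the data shown here, no step between two measured compounds is known for this exchange, so the size of the step from compound 1 to compound 3 has no direct precedent.

Compound 3 is expected to give 10000 nM in this assay, within 3000 nM to 30000 nM. The step of no change at the digits printed from compound 1 to compound 3 (within the scatter) is thus expected to be no change beyond the scatter, since compound 2 gives 10000 nM and compound 1 gives 10000 nM.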

Compound 3, concentration for 50% growth inhibition: 25000 nM
For compound 3 the middle estimate is 2.5-fold (0.40 log units) below the measured one, and the stated range covers the measured number.
By their numbers in this assay, from the lowest: compounds 1 and 2 (each within the scatter of the next); then compound 3.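

In this assay there is a 2.5-fold higher number from compound 1 to compound 3 (0.40 log units; beyond the scatter) with 3-methylthiophen-2-yl in place of 4-hydroxyphenyl on a double-bonded chain carbon bound to a double-bonded chain carbon. Among these compounds, this is the first step that can be read, and it shows that the number responds to the group at this place, moving towards weaker inhibition of growth when 4-hydroxyphenyl leaves. No measurement at hand bears on the reason for this step.

The exchange alters the ring size, the hetero atom, the methyl and the hydroxyl together, so these two compounds cannot assign the step to any one of them. On these data alone, whether an unsubstituted thiophen-2-yl or a 4-aminophenyl at this place would stay with compound 1 or with compound 3 remains open.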